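Acetyl on the ring amine, tested on a second core

The source may report more compounds than this note shows. Statements on the series, on what has been measured and on what is new or still open speak of the compounds shown alone.

Compound 1 `Nc1cc(OCc2ccccc2)nc(SCc2ccccc2)n1` and compound 2 `CC(=O)Nc1cc(OCc2ccccc2)nc(SCc2ccccc2)n1` share one core. In a functional assay on HT-29 cells (Homo sapiens) for antiproliferative activity, read by MTT assay, with a stated time of 72 h (on this read-out lower numbers stand for stronger inhibition of growth and higher numbers for weaker inhibition of growth), compound 1 gives 53900 nM, and compound 2 gives 65800 nM. The change between them, (acetyl in place of hydrogen on a nitrogen on an aromatic ring), made a 1.2-fold higher number from compound 1 to compound 2 (0.09 log units; within the scatter). Compound 3 `Nc1cc(=O)n(Cc2ccccc2)c(SCc2ccccc2)n1` is built from the same atoms as compound 1, joined differently; the difference between the two cores is not broken down here. In this assay compound 3 gives 100000 nM, within the scatter of both compound 1 and compound 2. Compound 4 `CC(=O)Nc1cc(=O)n(Cc2ccccc2)c(SCc2ccccc2)n1` differs from compound 3 by acetyl in place of hydrogen on a nitrogen on an aromatic ring, the same change as before at the same kind of place. The step from compound 3 to compound 4 is expected to be a 1.1-fold higher number from compound 3 to compound 4 (0.04 log units; within the scatter), small, because a 1.2-fold higher number from compound 1 to compound 2 (0.09 log units; within the scatter) was itself within the scatter. Compound 4 is therefore expected to give 110000 nM, estimated between 55000 nM and 250000 nM.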

Compound 4, concentration for 50% growth inhibition: 79300 nM
Compound 4: the middle estimate sits 1.4-fold (0.14 log units) above what was measured, within the range that was stated.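

In this assay the acetyl change on the second core gives a 1.3-fold lower number from compound 3 to compound 4 (0.10 log units; within the scatter) and so stays as small as it was on the first core. The two cores agree as far as this measurement can separate them: the same change on two cores in this assay, a 1.2-fold higher number (0.09 log units; within the scatter) from compound 1 to compound 2 and a 1.3-fold lower number (0.10 log units; within the scatter) from compound 3 to compound 4, 1.5-fold (0.19 log units) apart, within the scatter of two such steps

This shows that the change carries over from one core to the other as a step too small to read. It does not show a real effect of acetyl on either core, or what the change would do on any further core.

The compounds shown leave open whether a different group on that nitrogen, such as a longer acyl chain or a simple methyl, would give a step beyond the scatter.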